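This account rests on a few compounds, and the source may have more. Where it says the series, first, only, none or still open, it means among the compounds named here.

Measured compounds:
compound 1, `COc1ccc(/C=C/C2CC=CC(=O)O2)c(OC)c1`, 4.6 uM
compound 2, `COc1cc(OC)c(OC)cc1/C=C/C1CC=CC(=O)O1`, 11.5 uM
compound 3, `COc1cc(/C=C/C2CC=CC(=O)N2)cc(OC)c1`, 170 uM

All three were tested in a functional assay on U-251 cells (Homo sapiens) for inhibition, read by sulforhodamine B assay, with a stated time of 48 h; a lower number here means a stronger inhibitor of growth, a higher number a weaker inhibitor of growth. Compound 1 and compound 2 share a core; compound 3 has a different core, and the difference between the two cores is not broken down here. Compound 4, `COc1cc(/C=C/C2CC=CC(=O)N2)cc(OC)c1OC`, is unmeasured and differs from compound 3 by methoxy in place of hydrogen on an aromatic carbon. The change from compound 1 to compound 2 is methoxy in place of hydrogen on an aromatic carbon, the same kind of change, though around the place the surroundings differ: in compound 4 the new methoxy is ortho to two methoxy groups and para to the nine-atom group, whereas in compound 2 it is ortho to one methoxy, meta to the nine-atom group and para to a methoxy. That earlier step gave a 2.5-fold higher number from compound 1 to compound 2 (0.40 log units; beyond the scatter). For compound 4 a step of similar size is expected, a 2.1-fold higher number from compound 3 to compound 4 (0.31 log units; beyond the scatter), resting on that single precedent; compound 4 is estimated at 350 uM, between 150 uM and 900 uM.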

Compound 4, concentration for growth inhibition (reported as GI): > 864 uM
Compound 4 gave a limit, no number; the forecaster's own chance of this, stated with the estimate: 35%; middle value at least 2.4-fold (0.39 log units) away from the limit.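

In this assay compound 4 gives > 864 uM, which is a limit of the assay and not a number. Methoxy in place of hydrogen on an aromatic carbon still gives a readable step, an at least 5.0-fold higher number from compound 3 to compound 4 (0.70 log units; beyond the scatter), in the same direction as the step on the other core. So the direction of this change carries over between these two cores, but whether its size also carries over is not shown: the same change on two cores in this assay, a 2.5-fold higher number (0.40 log units; beyond the scatter) from compound 1 to compound 2 and an at least 5.0-fold higher number (0.70 log units; beyond the scatter) from compound 3 to compound 4; the limit leaves it open whether they differ

With one pair on each core, the compounds shown leave open whether the same direction would hold on any further core. They also leave open how a hydroxyl or an amine at the same place on the ring would compare with methoxy.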